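Swapping the Terminal Ring on a Urea Inhibitor

A few compounds are considered here, and "the series" means these few. Any claim that something is new, unique, unknown or untested is made for them only; others in the source may bear on it.

Compound 1 `Cc1cc(C)c(NC(=O)N(Cc2ccc(-c3nnc(C)o3)cc2)C2CCCCCC2)c(C)c1` and compound 2 `Cc1cc(C)c(NC(=O)N(Cc2ccc(-c3ccsc3)cc2)C2CCCCCC2)c(C)c1` share one core and differ only in the group carried on an aromatic carbon at its far end. In an assay on microsomes from intestine for inhibition of acyl-CoA:cholesterol acyltransferase (Oryctolagus cuniculus) (on this read-out lower numbers stand for stronger inhibition and higher numbers for weaker inhibition), compound 1 gives 27 nM and compound 2 gives 19 nM. Among the measured compounds shown here, the single measured step, a 1.4-fold lower number from compound 1 to compound 2 (0.15 log units; within the scatter), is within the scatter, so compound 2 gives the lower of the two numbers but the gap does not separate it from compound 1. Compound 3 `Cc1cc(C)c(NC(=O)N(Cc2ccc(-c3ccccn3)cc2)C2CCCCCC2)c(C)c1` arises from compound 2 by pyridin-2-yl in place of thiophen-3-yl on an aromatic carbon. For the measured compounds named here, only that one step bears on this change, and because a 1.4-fold lower number from compound 1 to compound 2 (0.15 log units; within the scatter) barely moved the number, exchanging one small aromatic ring for another is expected to leave this assay largely unchanged, with no step beyond the scatter. Compound 3 is therefore estimated at 25 nM, within a range from 10 nM to 70 nM. That estimate corresponds to the expected step of a 1.3-fold higher number from compound 2 to compound 3 (0.12 log units; within the scatter).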

Compound 3, half-maximal inhibitory concentration: 33 nM
Compound 3: the middle estimate sits 1.3-fold (0.12 log units) below what was measured, and the stated range covers the measured number.
By their numbers in this assay, from the lowest: compounds 2, 1 and 3 (each within the scatter of the next).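

The group on the aromatic carbon para to a large group now has a six-membered aromatic ring among its forms, and in this assay pyridin-2-yl sits level with both earlier groups. Neither step, a 1.7-fold higher number from compound 2 to compound 3 (0.24 log units; within the scatter) nor a 1.2-fold higher number from compound 1 to compound 3 (0.09 log units; within the scatter), lies beyond the scatter, so compounds 1, 2 and 3 cannot be told apart here, and this position has so far accepted thiophen-3-yl, 5-methyl-1,3,4-oxadiazol-2-yl and pyridin-2-yl alike. Nothing available explains why these three rings give such similar numbers.

On these data alone, all three groups are aromatic rings, so it remains open whether this position needs an aromatic ring at all. An amine, a carboxylic acid or a morpholine ring in the same place could test how far that tolerance extends.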